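A few compounds are considered here, and "the series" means these few. Any claim that something is new, unique, unknown or untested is made for them only; others in the source may bear on it.

In a functional assay on HCT-116 cells (Homo sapiens) for cytotoxicity, read by sulforhodamine B assay, with a stated time of 72 h (a lower number here means a stronger inhibitor, a higher number a weaker inhibitor), compound 1 (`OCC1=C(F)[C@@H](n2cnc3c(O)ncnc32)[C@H](O)[C@@H]1O`) gives > 100000 nM, which is a limit of the assay and not a number. Compound 2 (`Nc1nc(O)c2ncn([C@@H]3C(F)=C(CO)[C@@H](O)[C@H]3O)c2n1`) gives > 100000 nM, which is also a limit and not a number. Compound 2 therefore has no measured potency to start from, and the whole record so far is the limit of > 100000 nM in this assay, at which 2 of the 2 values shown sit.

Compound 3 (`Nc1nc(N)c2ncn([C@@H]3C(F)=C(CO)[C@@H](O)[C@H]3O)c2n1`) keeps the core of compound 2 and changes one group: amino in place of hydroxy on an aromatic carbon. This is amino in place of hydroxy on an aromatic carbon, next to the ring nitrogen.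

Among the measured compounds shown here, the one measured step that bears on this is a step that the two limits leave unreadable from compound 1 to compound 2. It also brings in an amino group on an aromatic carbon, but it replaces hydrogen rather than hydroxy, and it offers no size to carry over. The expectation is therefore loose: a move towards a stronger inhibitor is possible, and another result at the limit would be no surprise. The expected step, an at least 5.0-fold lower number from compound 2 to compound 3 (0.69 log units; beyond the scatter), is only an estimate. In this assay, the estimated value for compound 3 is 20000 nM, with an expected range from 1000 nM to 100000 nM.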

Compound 3, half-maximal inhibitory concentration: 21900 nM
Estimate against measurement, compound 3: 1.1-fold (0.04 log units) below; low and high end bracket the measured number.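

In this assay, putting amino in place of hydroxy on the aromatic carbon next to the ring nitrogen gives an at least 4.5-fold lower number from compound 2 to compound 3 (0.65 log units; beyond the scatter). Among the compounds shown here, compound 3, at 21900 nM, is the first compound here with a readable number, and it shows that this position responds to the group placed on it, something the earlier compounds could not show, since the step between them cannot be read. On these data alone, the result for compound 2 is a limit and not a number, so the true size of this step stays unknown, and the record as a whole remains thin: the limit of > 100000 nM in this assay, at which 2 of the 3 values shown sit.

As far as these compounds go, whether a larger group at this position, such as methylamino or methoxy, or a halogen such as chlorine, would lower the number further or lose the gain stays open. Also open, from the compounds shown here alone, is whether the same change of hydroxy to amino would give a readable number on compound 1, which lacks the amino group that compound 2 and compound 3 carry on their other aromatic carbon.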